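Aryl variation on a methoxime piperazine series

A few compounds are considered here, and "the series" means these few. Any claim that something is new, unique, unknown or untested is made for them only; others in the source may bear on it.

Measured so far:
compound 1 `CO/N=C(/CCN1CCN(c2ccccn2)CC1)c1ccccc1C` — 40.1 nM
compound 2 `CO/N=C(/CCN1CCN(c2ccccn2)CC1)c1cc(C)cc(C)c1` — 74.7 nM

Among the measured compounds shown here, in a functional assay on HEK293 cells with D(4) dopamine receptor (Homo sapiens) as the target, read by FLIPR (a higher number here means that more compound is needed for the effect, a lower number that less compound is needed), compound 2 gives 74.7 nM, the higher of the two numbers obtained; the only neighbour is compound 1, and a 1.9-fold higher number from compound 1 to compound 2 (0.27 log units; within the scatter), so the two stand together within the scatter.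

Compound 3 `CO/N=C(/CCN1CCN(c2ccccn2)CC1)c1ccc(Cl)c(Cl)c1` carries the change (3,4-dichlorophenyl in place of 3,5-dimethylphenyl on a carbon with a double bond to nitrogen). For the measured compounds named here, no measured step covers this exchange. Going by the values given here, the single step available, a 1.9-fold higher number from compound 1 to compound 2 (0.27 log units; within the scatter), alters the same group on the same carbon and stayed within the scatter. On that basis a step beyond the scatter is not expected in this assay for compound 3, with no direction favoured; the expected step is a 1.1-fold lower number from compound 2 to compound 3 (0.03 log units; within the scatter). The estimate for compound 3 is 70 nM, with a range from 25 nM to 250 nM to cover the uncertainty of an untested exchange.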

Compound 3, half-maximal effective concentration: 341 nM
Compound 3: middle estimate off by 4.9-fold (0.69 log units), on the low side; measured number outside the range, above it.
By their numbers in this assay, from the lowest: compounds 1 and 2 (each within the scatter of the next); then compound 3.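

In this assay, the group on the carbon with a double bond to nitrogen can move the number beyond the scatter, which the earlier pair did not show (a 4.6-fold higher number from compound 2 to compound 3 (0.66 log units; beyond the scatter); an 8.5-fold higher number from compound 1 to compound 3 (0.93 log units; beyond the scatter)). Both steps are modest, yet the exchange for 3,4-dichlorophenyl sets compound 3 apart from compounds 1 and 2, whose 2-methylphenyl and 3,5-dimethylphenyl groups stand within the scatter of each other. No available measurement accounts for this step.

Open, on these data alone, is whether the step follows the chlorine atoms or their placing, as 3,4-dichlorophenyl and 3,5-dimethylphenyl differ in both. Also open, as far as these compounds go, is how a phenyl carrying a single chlorine, an amine or a carboxylic acid would stand on this carbon.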